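Bis-aryl substitution on the indole-nitrogen carbon of compound 3

The compounds below may be only part of what the source reports. "The series", "measured", "known", "first", "only" and "open" are said of these compounds alone.

Compound 3 `CCC(c1ccccc1)n1ccc2cc(/C(C)=C/C(=O)Nc3ccccc3OCCCC(=O)O)ccc21` gives the lowest number of the three measured, at 19 nM in an assay on Prostate gland for inhibition of steroid 5-alpha-reductase (Rattus norvegicus); a lower number here means a stronger inhibitor, a higher number a weaker inhibitor. Compound 1 `C/C(=C\C(=O)Nc1ccccc1OCCCC(=O)O)c1ccc2c(ccn2CC(C)C)c1` gives 160 nM and compound 2 `C/C(=C\C(=O)Nc1ccccc1OCCCC(=O)O)c1ccc2c(ccn2Cc2ccccc2C)c1` gives 69 nM. Compound 4 `COc1ccc(C(c2ccccc2)n2ccc3cc(/C(C)=C/C(=O)Nc4ccccc4OCCCC(=O)O)ccc32)cc1` is not yet measured; it differs from compound 3 by 4-methoxyphenyl in place of ethyl on a saturated chain carbon bound to an aromatic carbon and an aromatic nitrogen. The measured steps all concern the group on the aromatic nitrogen: an 8.4-fold lower number from compound 1 to compound 3 (0.93 log units; beyond the scatter), a 3.6-fold lower number from compound 2 to compound 3 (0.56 log units; beyond the scatter) and a 2.3-fold lower number from compound 1 to compound 2 (0.37 log units; beyond the scatter). Each larger, aryl-bearing group gave a lower number, but none adds a second aromatic ring on the same chain carbon, so a modest further gain or none beyond the scatter is expected. For compound 4 the estimate is 12 nM, range 4 nM to 40 nM, an expected step of a 1.6-fold lower number from compound 3 to compound 4 (0.20 log units; within the scatter).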

Compound 4, half-maximal inhibitory concentration: 8.8 nM
Beside the measured number, compound 4's estimate is 1.4-fold (0.13 log units) above it; the measured number falls inside the stated range.
By their numbers in this assay, from the lowest: compound 4; then compound 3; then compound 2; then compound 1.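

Putting 4-methoxyphenyl in place of ethyl on the saturated chain carbon bound to an aromatic carbon and an aromatic nitrogen gives a 2.2-fold lower number from compound 3 to compound 4 (0.33 log units; beyond the scatter) in this assay. Compound 4 is the first compound shown with two aromatic rings on this carbon, and the number still falls, by a step beyond the scatter. Nothing available explains the gain.

Still open, going by these compounds, is whether the gain needs the methoxy group or only the second ring. A plain phenyl in place of 4-methoxyphenyl, or a 4-fluorophenyl, would separate the two.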